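Lipoic acid coumarin hybrids: a second methoxy group

A few compounds are considered here, and "the series" means these few. Any claim that something is new, unique, unknown or untested is made for them only; others in the source may bear on it.

Compound 1 `O=C(CCCCC1CCSS1)NCc1cn(CCCOc2ccc3cc(-c4ccccc4)c(=O)oc3c2)nn1` in a functional assay on PC-12 cells (Rattus norvegicus) for cytotoxicity, read by MTT assay, with stated times of 3 h and 2 h, tested at 1 uM; a lower number here means a weaker effect, a higher number a stronger effect of the compound at the concentration tested: 31.9%
Compound 2 `COc1ccc(-c2cc3ccc(OCCCn4cc(CNC(=O)CCCCC5CCSS5)nn4)cc3oc2=O)cc1` in this assay: 47.4%
Compound 3 `COc1ccc(-c2cc3ccc(OCCCCCn4cc(CNC(=O)CCCCC5CCSS5)nn4)cc3oc2=O)cc1` in this assay: 37.1%

From compound 1 to compound 2 the change is methoxy in place of hydrogen on an aromatic carbon. This gave a number 15.5 percentage points higher from compound 1 to compound 2 (beyond the scatter). Compound 3 has a different core from compound 1; the difference between the two cores is not broken down here. Compound 4 `COc1ccc(-c2cc3ccc(OCCCCCn4cc(CNC(=O)CCCCC5CCSS5)nn4)cc3oc2=O)cc1OC` has not yet been measured in this assay. It differs from compound 3 by methoxy in place of hydrogen on an aromatic carbon. In compound 2 the entering group sits para to a large group, while in compound 4 it sits ortho to a methoxy group and meta to a large group, so this is the same kind of change rather than the same change. Going by the values given here, the expectation rests on the single earlier step of a number 15.5 percentage points higher from compound 1 to compound 2 (beyond the scatter), and a smaller step is expected for compound 4, namely a number 7.9 percentage points higher from compound 3 to compound 4 (within the scatter). Compound 4 is therefore estimated at 45%, most likely between 31% and 60%.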

Compound 4, a percentage reported as activity, at one concentration (the size of the read-out at that concentration, not a potency): 42.2%
For compound 4 the middle estimate is 2.8 percentage points above the measured one, within the range that was stated.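

In this assay, going from 4-methoxyphenyl to 3,4-dimethoxyphenyl gave a number 5.1 percentage points higher from compound 3 to compound 4 (within the scatter), so on this core the change stays inside the usual spread of repeated measurements. Set beside the earlier step, the new one cannot be told apart from it: the same change on two cores in this assay, a number 15.5 percentage points higher (beyond the scatter) from compound 1 to compound 2 and a number 5.1 percentage points higher (within the scatter) from compound 3 to compound 4, 10.4 percentage points apart, within the scatter of two such steps

Going by these compounds alone, this shows that the two results are compatible with a single step size across the two cores, but it does not show that the change carries over unchanged, as there are only two steps, the methoxy group enters at a different place in each, and only the earlier step stands beyond the scatter.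

The compounds shown leave open how an amine or a carboxylic acid would read at this place on the aromatic ring. They also leave open how the same methoxy step would read on a core with a longer chain.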